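A Side Chain Swap at the Cytotoxicity Limit

The source may report more compounds than this note shows. Statements on the series, on what has been measured and on what is new or still open speak of the compounds shown alone.

Compound 1 (`CC(C)CCn1nc(-c2ccccc2)c(O)c(C2=NS(=O)(=O)c3cc(NS(C)(=O)=O)ccc3N2)c1=O`), compound 2 (`CC(C)CCn1nc(C2CCC2)c(O)c(C2=NS(=O)(=O)c3cc(NS(C)(=O)=O)ccc3N2)c1=O`) and compound 3 (`CC(C)CCn1nc(CC2CCC2)c(O)c(C2=NS(=O)(=O)c3cc(NS(C)(=O)=O)ccc3N2)c1=O`) share one core and differ only in the group on a single aromatic carbon. In an ADME assay on Huh-7 cells (Homo sapiens) for cytotoxicity, with a stated time of 72 h (on this read-out higher numbers stand for lower toxicity in this test and lower numbers for higher toxicity in this test), compound 1, which carries phenyl, gives > 1000 nM as a limit of the assay, not a number. Compound 2, which carries cyclobutyl, gives > 33000 nM as a limit too. Compound 3, which carries cyclobutylmethyl, gives > 33000 nM as a limit as well. Compound 3 therefore stands at the limit of > 33000 nM in this assay, at which 2 of the 3 values shown sit, and has no exact value.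

Compound 4 (`C/C(=C\c1nn(CCC(C)C)c(=O)c(C2=NS(=O)(=O)c3cc(NS(C)(=O)=O)ccc3N2)c1O)C(F)(F)F`) keeps the core but has 2-(trifluoromethyl)prop-1-en-1-yl in place of cyclobutylmethyl on that aromatic carbon (2-(trifluoromethyl)prop-1-en-1-yl in place of cyclobutylmethyl on an aromatic carbon). Two measured changes on this carbon bear on the new step (a step that the two limits leave unreadable from compound 2 to compound 3) and (a step that the two limits leave unreadable from compound 1 to compound 3) but neither has a size that can be carried over. The expectation therefore rests on compound 3 with its limit of > 33000 nM in this assay, and no step beyond the scatter is expected in either direction. The expected change (a number no higher from compound 3 to compound 4 (the limit leaves the size open)) is only an estimate. For compound 4 the estimate is 33000 nM with an expected range from 8000 nM to 70000 nM and a limit rather than an exact number is expected.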

Compound 4, half-maximal cytotoxic concentration: > 33000 nM
Compound 4: no number, only a limit; the forecaster's own chance of this, stated with the estimate: 75%; the middle value sits exactly at the limit.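

Compound 4 gives > 33000 nM, which is a limit of the assay and not a number. Its steps from compound 1, compound 2 and compound 3 cannot be read, as each joins two limits. Left open is the exact concentration at which each of these four compounds becomes toxic in this assay, and whether their groups make any difference there.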